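Swapping an Amide for an Ester Chain on a Shared Core

The source may hold more compounds than are shown below. What is called first, only, known or untested is meant among the compounds shown, and "the series" means these compounds.

Compound 1, `CCOC(=O)c1ccc(-c2nn(Cc3ccccn3)c3ccccc23)cc1`: 290 nM
Compound 2, `NC(=O)c1ccc(-c2nn(Cc3ccccc3)c3ccccc23)cc1`: > 10000 nM

In a functional assay on cells (Platelet, Homo sapiens) for inhibition (on this read-out higher numbers stand for weaker inhibition and lower numbers for stronger inhibition), compound 1 gives 290 nM. Compound 2 is reported only as a limit of the measurement, > 10000 nM, so compound 2 stands at the weak end of what this assay can report (the limit of > 10000 nM in this assay, at which 1 of the 2 values shown sits). Compound 3, `CCOC(=O)/C=C/c1ccc(-c2nn(Cc3ccccc3)c3ccccc23)cc1`, has not yet been measured. It differs from compound 2 in one place: 2-(ethoxycarbonyl)ethenyl in place of carbamoyl on an aromatic carbon. Among the measured compounds shown here, no step between measured compounds that differ in just one place is available, so the size of this change can only be guessed. Compound 1, whose structure also contains an ethoxycarbonyl group, gives 290 nM in this assay, though it differs from compound 3 in more than one place. The step expected from this change, an at least 10-fold lower number from compound 2 to compound 3 (1.00 log units; beyond the scatter), should be a gain in inhibition beyond the usual scatter. Compound 3 is estimated at 1000 nM, with a range from 200 nM to 6000 nM.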

Compound 3, half-maximal inhibitory concentration: > 10000 nM
Compound 3: no number, only a limit; the forecaster's own chance of this, stated with the estimate: 25%; middle value at least 10-fold (1.00 log units) away from the limit.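

Among the compounds shown here, compound 3 is reported only as the limit > 10000 nM and compound 2 also only as a limit, so no step between them can be read in this assay: the limit of > 10000 nM in this assay, at which 2 of the 3 values shown sit.

Going by these compounds, whether 2-(ethoxycarbonyl)ethenyl and carbamoyl differ at all on this shared core stays open.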